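This account rests on a few compounds, and the source may have more. Where it says the series, first, only, none or still open, it means among the compounds named here.

Working notes on the urea-linked series sharing the core of compound 1.

Compound 1 `COc1cc(NC(C)CCCNC(=O)Nc2ccc(F)cc2)c2ncccc2c1` gives 26000 nM in a functional assay on NCI-H460 cells (Homo sapiens) for inhibition, read by MTT assay, with a stated time of 72 h (a higher number here means a weaker inhibitor, a lower number a stronger inhibitor), the lowest of the two numbers on hand. Compound 3 `COc1cc(NC(C)CCCNC(=O)Nc2cccc(Cl)c2)c2ncccc2c1` gives 37000 nM in this assay, and the step of a 1.4-fold higher number from compound 1 to compound 3 (0.15 log units; within the scatter) shows that exchanging one aryl ring for another here stays within the scatter. Compound 2 `COc1cc(NC(C)CCCNC(=O)NNC(=O)Nc2ccc(F)cc2)c2ncccc2c1` gives > 100000 nM in this assay, a limit and not a number. The step of an at least 3.8-fold higher number from compound 1 to compound 2 (0.58 log units; beyond the scatter) is bounded by the limit of > 100000 nM in this assay, at which 1 of the 3 values shown sits, and the same limit bounds an at least 2.7-fold lower number from compound 2 to compound 3 (0.43 log units; beyond the scatter); both steps concern the insertion of a further urea-type unit rather than a change of ring substituent.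

Compound 4 `COc1cc(NC(C)CCCNC(=O)Nc2cccc(C(F)(F)F)c2)c2ncccc2c1` is not yet measured. Relative to compound 1 the change is 3-(trifluoromethyl)phenyl in place of 4-fluorophenyl on an amide-type nitrogen. The step that bears on it is the ring exchange from compound 1 to compound 3, which stayed within the scatter; the steps to and from compound 2 are of a different kind and carry a limit. A step within the scatter, with no clear direction, is therefore expected for compound 4 in this assay. Compound 4 is estimated at 30000 nM, with a range of 12000 nM to 75000 nM, which means an expected step of a 1.2-fold higher number from compound 1 to compound 4 (0.06 log units; within the scatter).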

Compound 4, half-maximal inhibitory concentration: 21000 nM
Compound 4: the middle estimate sits 1.4-fold (0.15 log units) above what was measured; the range from low to high includes it.
By their numbers in this assay, from the lowest: compounds 4, 1 and 3 (each within the scatter of the next). At a limit, above all of these: compound 2.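

In this assay, a third aryl group on the amide-type nitrogen leaves the picture unchanged: a 1.2-fold lower number from compound 1 to compound 4 (0.09 log units; within the scatter), and a 1.8-fold lower number from compound 3 to compound 4 (0.25 log units; within the scatter). The second step adds a direct exchange of trifluoromethyl for chloro on an aromatic carbon, so 4-fluorophenyl, 3-chlorophenyl and 3-(trifluoromethyl)phenyl on this nitrogen cannot be ranked among compounds 1, 3 and 4, even though the entering group in compound 4 is the largest of the three by heavy-atom count. Compound 2 stands at a limit and not at a number, so an at least 4.7-fold lower number from compound 2 to compound 4 (0.67 log units; beyond the scatter) is a bound only, and among the compounds shown the one change beyond the scatter remains the extended urea-type unit: the limit of > 100000 nM in this assay, at which 1 of the 4 values shown sits.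

The compounds shown leave open whether any change at this nitrogen can lower the number beyond the scatter, for instance a ring bearing an amine or a carboxylic acid, or a saturated ring such as cyclohexyl in place of the aryl group. They also leave open how a longer or shorter chain linking the urea to the shared core would read in this assay.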